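Phenylsulfanyl to pyrazolyl on the acylguanidine series

The source may report more compounds than this note shows. Statements on the series, on what has been measured and on what is new or still open speak of the compounds shown alone.

The shared core carries an acylguanidine and a methylsulfonyl group, and the compounds differ at one aromatic carbon. In a functional assay for inhibition of sodium/hydrogen exchanger (Oryctolagus cuniculus) (a lower number here means a stronger inhibitor, a higher number a weaker inhibitor), compound 1 `Cc1cc(F)c(S(C)(=O)=O)cc1C(=O)N=C(N)N` gives 44 nM, compound 2 `CCC(C)c1cc(C)c(C(=O)N=C(N)N)cc1S(C)(=O)=O` gives 8 nM and compound 3 `Cc1cc(Sc2ccccc2)c(S(C)(=O)=O)cc1C(=O)N=C(N)N` gives 14 nM. Compound 3 stands second highest of the three measured values: its nearest neighbour is compound 2, within the scatter, and its furthest is compound 1, beyond the scatter. The measured steps are a 5.5-fold lower number from compound 1 to compound 2 (0.74 log units; beyond the scatter), a 3.1-fold lower number from compound 1 to compound 3 (0.50 log units; beyond the scatter) and a 1.8-fold higher number from compound 2 to compound 3 (0.24 log units; within the scatter).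

Compound 4 `Cc1cc(-n2cccn2)c(S(C)(=O)=O)cc1C(=O)N=C(N)N` is not yet measured. The change from compound 3 is 1H-pyrazol-1-yl in place of phenylsulfanyl on an aromatic carbon. Within the data shown here, no measured step involves a 1H-pyrazol-1-yl group, so the bearing of the existing steps is indirect: both sec-butyl and phenylsulfanyl gave modest steps beyond the scatter relative to fluoro, and the two of them sit within the scatter of each other. A five-membered aromatic ring with two hetero atoms is neither of those groups, and the data give no guide to its direction. The expectation for compound 4 is therefore a number near compound 3, with a step of a 1.8-fold higher number from compound 3 to compound 4 (0.25 log units; within the scatter) that is estimated to stay within the scatter but with wide uncertainty. The estimate for compound 4 is 25 nM, expected to fall between 8 nM and 80 nM.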

Compound 4, half-maximal inhibitory concentration: 25 nM
For compound 4 middle estimate and measured number coincide at the digits printed, within the range that was stated.
By their numbers in this assay, from the lowest: compounds 2, 3, 4 and 1 (each within the scatter of the next, the first and the last beyond it).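

In this assay, replacing phenylsulfanyl with 1H-pyrazol-1-yl gives a 1.8-fold higher number from compound 3 to compound 4 (0.25 log units; within the scatter), so on this one pair the aromatic carbon ortho to a methylsulfonyl group tolerates a five-membered aromatic ring with 2 hetero atoms in place of a six-membered aromatic ring of carbon only. Against fluoro, 1H-pyrazol-1-yl gives only a 1.8-fold lower number from compound 1 to compound 4 (0.25 log units; within the scatter), whereas sec-butyl and phenylsulfanyl both stood beyond the scatter from fluoro, and against sec-butyl it gives a 3.1-fold higher number from compound 2 to compound 4 (0.49 log units; beyond the scatter), so the three groups replacing fluoro no longer form a single unresolved set, even though compound 3 remains within the scatter of both compound 2 and compound 4. No measurement at hand offers an explanation for these steps.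

On these data alone, the role of the sulfur link in phenylsulfanyl remains open, and a phenyl ring bonded directly to the aromatic carbon or a phenoxy group at this place would test it. As far as these compounds go, whether the two nitrogens of 1H-pyrazol-1-yl matter also remains open, and a pyrrol-1-yl group, with one ring nitrogen, would address that.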